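The source may report more compounds than this note shows. Statements on the series, on what has been measured and on what is new or still open speak of the compounds shown alone.

In a functional assay on 3T3-L1 cells (Mus musculus) for inhibition, with a stated time of 20 min, tested at 20 uM (on this read-out lower numbers stand for less inhibition and higher numbers for more inhibition at the one concentration tested (going by the name of the read-out)), three compounds have been measured so far. Compound 3 `Cc1ccc(S(=O)(=O)N(Cc2cn(Cc3ccccc3)nn2)Cc2c(-c3ccccc3)c3ccccc3n2S(=O)(=O)c2ccc(C)cc2)cc1` gives 0.03%, and compound 1 `Cc1ccc(S(=O)(=O)N(Cc2cn(Cc3ccc(F)cc3)nn2)Cc2c(-c3ccccc3)c3ccccc3n2S(=O)(=O)c2ccc(C)cc2)cc1` gives -7.6%; the change between them is fluoro in place of hydrogen on an aromatic carbon, and the step is a number 7.6 percentage points lower from compound 3 to compound 1 (within the scatter). Compound 2 `Cc1ccc(S(=O)(=O)N(Cc2ccccc2)Cc2cccc(F)c2F)cc1` gives -35.7%; the difference between the core of compound 2 and the core of compound 3 is not broken down here. Compound 4 `Cc1ccc(S(=O)(=O)N(Cc2ccc(F)cc2)Cc2cccc(F)c2F)cc1` is not yet measured and differs from compound 2 by fluoro in place of hydrogen on an aromatic carbon, the same change that turns compound 3 into compound 1. Because a number 7.6 percentage points lower from compound 3 to compound 1 (within the scatter) stayed within the scatter, the step is expected to be small, a number 0.7 percentage points higher from compound 2 to compound 4 (within the scatter). Compound 4 is therefore estimated at -35%, between -55% and -15%.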

Compound 4, a percentage reported as inhibition, at one concentration (the size of the read-out at that concentration, not a potency): -97.7%
Compound 4: the middle estimate sits 62.7 percentage points above what was measured; the whole stated range lies above it.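

In this assay, fluoro in place of hydrogen on an aromatic carbon gives a large step on the core of compound 2, a number 62 percentage points lower from compound 2 to compound 4 (beyond the scatter), so the size of this step did not carry over from one core to the other: the same change on two cores in this assay, a number 7.6 percentage points lower (within the scatter) from compound 3 to compound 1 and a number 62 percentage points lower (beyond the scatter) from compound 2 to compound 4, 54.4 percentage points apart, beyond the scatter of two such steps.

This shows that, in this series, a step measured on one core is not a safe guide to the same change on another core. Among these compounds, with only two pairs, it does not show which part of the cores is responsible, why the steps differ, or how the change would behave on a third core.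

The compounds shown leave open what other groups on the same aromatic carbon, such as chloro, an amine or a carboxylic acid, would do on either core. They also leave open how these compounds behave at other concentrations.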